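The compounds below may be only part of what the source reports. "The series", "measured", "known", "first", "only" and "open" are said of these compounds alone.

Compound 1, with the structure `COc1cccc(/C=C2\CCC/C(=C\c3ccc(O)c(Cl)c3)C2=O)c1OC`, gives 16800 nM in a functional assay on SW-620 cells (Homo sapiens) for cytotoxicity, read by MTT assay, with a stated time of 72 h; on this read-out lower numbers stand for stronger inhibition and higher numbers for weaker inhibition. Compound 2, `COc1cc(/C=C2\CCC/C(=C\c3cccc(OC)c3OC)C2=O)ccc1O`, gives 8600 nM in this assay; the change from compound 1 is methoxy in place of chloro on an aromatic carbon, and the step of a 2.0-fold lower number from compound 1 to compound 2 (0.29 log units; within the scatter) is small. Compound 3, `COc1ccc(/C=C2\CCC/C(=C\c3ccc(O)c(Cl)c3)C2=O)cc1OC`, gives 7100 nM in this assay. Its core is built from the same atoms as the core of compound 1 but joined differently; the difference between the two cores is not broken down here. The values of compound 2 and compound 3 lie close together, so nothing separates them.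

Compound 4, `COc1cc(/C=C2\CCC/C(=C\c3ccc(OC)c(OC)c3)C2=O)ccc1O`, has not been measured. It differs from compound 3 by methoxy in place of chloro on an aromatic carbon, the same change that turned compound 1 into compound 2, made at a place that reads the same word for word. Among the compounds with values here, the expected step from compound 3 is a 1.8-fold lower number from compound 3 to compound 4 (0.25 log units; within the scatter), a number of the same order as the earlier step, because a 2.0-fold lower number from compound 1 to compound 2 (0.29 log units; within the scatter) is the only instance of this change measured here. For compound 4 the estimated value in this assay is 4000 nM, with a plausible range from 1800 nM to 9000 nM.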

Compound 4, half-maximal inhibitory concentration: 4500 nM
Compound 4: middle estimate off by 1.1-fold (0.05 log units), on the low side; measured number inside the range.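

Putting methoxy in place of chloro on the 3-chloro-4-hydroxyphenyl group gives a 1.6-fold lower number from compound 3 to compound 4 (0.20 log units; within the scatter) in this assay. Set beside the earlier case, the two steps agree: the same change on two cores in this assay, a 2.0-fold lower number (0.29 log units; within the scatter) from compound 1 to compound 2 and a 1.6-fold lower number (0.20 log units; within the scatter) from compound 3 to compound 4, 1.2-fold (0.09 log units) apart, within the scatter of two such steps. The change therefore carries across these two cores with no visible difference in step size, but each step is itself within the usual scatter of repeated measurements, so neither shows a real gain in potency, and two cores cannot support a rule for the whole series.

At this place on the aromatic ring, the compounds shown carry only chloro or methoxy, so it remains open how an amine, a carboxylic acid or a longer chain such as ethoxy would read there. On these data alone, all the values shown also come from one assay on one cell line, so whether the same steps would appear in other cells remains open too.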